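This account rests on a few compounds, and the source may have more. Where it says the series, first, only, none or still open, it means among the compounds named here.

Measured compounds:
Compound 1, `CCCCc1ccc2c(c1)C(=O)C(=O)N2` — > 10000 nM
Compound 2, `COC(=O)/C=C/c1ccc2c(c1)C(=O)C(=O)N2` — 200 nM
Compound 3, `COC(=O)/C=C/c1ccc2c(c1)C(=O)C(=O)N2Cc1ccc(C#N)cc1` — 80 nM

The three compounds share one core and were tested in a functional assay on Jurkat cells (Homo sapiens) for antiproliferative activity, read by MTT assay, with a stated time of 48 h; on this read-out lower numbers stand for stronger inhibition and higher numbers for weaker inhibition. Compound 1 reaches only the limit of that assay, > 10000 nM, so for it no number is available (the limit of > 10000 nM in this assay, at which 1 of the 3 values shown sits). Compound 2 gives 200 nM. Compound 3 gives 80 nM, the lowest of the two numbers recorded; the gap between compound 2 and compound 3 lies beyond the usual scatter of repeated measurements.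

The next compound, compound 4, `COC(=O)/C=C/c1ccc2c(c1)C(=O)C(=O)N2Cc1ccc(OC)cc1`, is not yet measured. It differs from compound 3 in one place: methoxy in place of cyano on an aromatic carbon, on an aromatic carbon of a six-membered aromatic ring of carbon only, para to a large group. No measured pair among the compounds shown changes this position, so no measured step can be drawn on.

Among the compounds with values here, with no measured step to go by, the expected step in this assay is small, and the estimate for compound 4 is 120 nM, with a range from 40 nM to 400 nM. The expected step from compound 3 to compound 4 is a 1.5-fold higher number from compound 3 to compound 4 (0.18 log units; within the scatter), which is within the scatter rather than a clear change in either direction.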

Compound 4, half-maximal inhibitory concentration: 30 nM
The estimate for compound 4 lay 4.0-fold (0.60 log units) above the measured number; measured number outside the range, below it.
By their numbers in this assay, from the lowest: compound 4; then compound 3; then compound 2. At a limit, above all of these: compound 1.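

In this assay, methoxy in place of cyano gives a 2.7-fold lower number from compound 3 to compound 4 (0.43 log units; beyond the scatter), a modest step but one beyond the usual scatter, so the group held on this aromatic carbon, para to a large group, has a measurable bearing on the read-out. Within the data shown here, the earlier compounds could not show this, as none of them varied this position, and this is the first measured step at it: two groups of the same heavy-atom count, each with one hydrogen-bond acceptor and neither with a donor, give clearly different numbers, so those counts alone do not settle the value here. Nothing among the data shown accounts for why the methoxy compound gives the lower number, as no measurement here bears on the cause of this step.

With only these two groups at this position, the compounds shown leave open whether the trend would continue to a longer chain such as ethoxy or butoxy, or how a hydroxyl, an amine or a carboxylic acid would read in the same place. They also leave open whether methoxy would give a similar step on another carbon of this ring.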